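Piperidin-1-yl for Pyrrolidin-1-yl on Two Cores

This account rests on a few compounds, and the source may have more. Where it says the series, first, only, none or still open, it means among the compounds named here.

Two cores are compared in an assay on isolated protein for inhibition of protein deacetylase HDAC6 (Homo sapiens), tested at 0.5 uM; a higher number here means more inhibition at the concentration tested (going by the name of the read-out), a lower number less inhibition. Compound 1 `O=C(NO)c1ccc(-c2nc(N3CCCC3)c3ccccc3n2)cc1` gives 57.2%, and compound 2 `O=C(NO)c1ccc(-c2nc(N3CCCCC3)c3ccccc3n2)cc1`, which carries piperidin-1-yl in place of pyrrolidin-1-yl on an aromatic carbon, gives 66.4%. That step, a number 9.2 percentage points higher from compound 1 to compound 2 (within the scatter), is a modest one. Compound 3 `COc1cc(OC)c2c(N3CCCC3)nc(-c3ccc(C(=O)NO)cc3)nc2c1` rests on a different core; how the two cores differ is not broken down here. In this assay compound 3 gives 55.3%. Compound 4 `COc1cc(OC)c2c(N3CCCCC3)nc(-c3ccc(C(=O)NO)cc3)nc2c1` has not yet been measured and differs from compound 3 by piperidin-1-yl in place of pyrrolidin-1-yl on an aromatic carbon, the same change that was made from compound 1 to compound 2, at a place described in the same words. Because the earlier step of a number 9.2 percentage points higher from compound 1 to compound 2 (within the scatter) stayed within the scatter, a step of similar size is expected here, a number 8.7 percentage points higher from compound 3 to compound 4 (within the scatter). Compound 4 is therefore expected to give about 64%, between 54% and 74%.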

Compound 4, a percentage reported as inhibition, at one concentration (the size of the read-out at that concentration, not a potency): 62.5%
Beside the measured number, compound 4's estimate is 1.5 percentage points above it, within the range that was stated.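

With piperidin-1-yl in place of pyrrolidin-1-yl, this assay gives a number 7.2 percentage points higher from compound 3 to compound 4 (within the scatter), and the two cores show no difference in how they take this change: the same change on two cores in this assay, a number 9.2 percentage points higher (within the scatter) from compound 1 to compound 2 and a number 7.2 percentage points higher (within the scatter) from compound 3 to compound 4, 2 percentage points apart, within the scatter of two such steps. Among these compounds, this agreement supports carrying the change between these two cores, but it rests on only two pairs of compounds. Each step also lies within the scatter, so neither pair shows that the change truly alters inhibition, and a reading at one concentration is not a potency.

The compounds shown leave open how other amines at this place, such as morpholin-4-yl or dimethylamino, would compare. From the compounds shown here alone, whether the same agreement would hold on a third core also remains unknown.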